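Removing a Side Chain from Compound 1

A few compounds are considered here, and "the series" means these few. Any claim that something is new, unique, unknown or untested is made for them only; others in the source may bear on it.

Compound 1 `CC(=O)CC[C@]1(C(C)=O)C(=O)O[C@@H](OC(C)=O)[C@H]1C`: 8000 nM
Compound 2 `CC(=O)[C@@]1(C)C(=O)O[C@@H](OC(=O)c2ccccc2)[C@H]1C`: 1000 nM
Compound 3 `CC(=O)O[C@@H]1OC(=O)[C@@](C)(C(C)=O)[C@@H]1C`: 9000 nM

Of the compounds shown here, three have been tested in a functional assay on DA-3 cells for cytotoxicity against DA-3 cell line (Mus musculus), read by MTT assay; on this read-out higher numbers stand for weaker inhibition and lower numbers for stronger inhibition. Compound 1 gives 8000 nM, the second highest of the three numbers. Compound 3 gives 9000 nM, within the usual scatter of compound 1, so the two cannot be told apart. Compound 2 gives 1000 nM, a lower number that lies beyond the scatter.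

Compound 4 `CC(=O)O[C@@H]1OC(=O)[C@@H](C(C)=O)[C@@H]1C` has not been measured. It differs from compound 1 by hydrogen in place of 2-acetylethyl on a saturated ring carbon. Going by the values given here, no pair of measured compounds shows this kind of change, so the expectation rests on the values alone. Compound 4 is expected to stay near compound 1, with the step of a 1.5-fold higher number from compound 1 to compound 4 (0.18 log units; within the scatter) leaning slightly toward weaker inhibition. The estimate for compound 4 is 12000 nM, within a range from 4000 nM to 40000 nM.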

Compound 4, half-maximal inhibitory concentration: > 50000 nM
Compound 4: only a limit was reported (the forecaster's own chance of this, stated with the estimate: 15%); middle value at least 4.1-fold (0.61 log units) from the limit.
By their numbers in this assay, from the lowest: compound 2; then compounds 1 and 3 (each within the scatter of the next). At a limit, above all of these: compound 4.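

In this assay, going by these compounds alone, this is the first change at a single place that can be read: hydrogen in place of 2-acetylethyl on this saturated ring carbon gives an at least 6.2-fold higher number from compound 1 to compound 4 (0.79 log units; beyond the scatter). For compound 4, > 50000 nM is a limit and not a number: the limit of > 50000 nM in this assay, at which 1 of the 4 values shown sits.

This ring carbon is therefore not indifferent to what it carries, as bare hydrogen here goes with clearly weaker inhibition. Still open, as far as these compounds go, is how an amine, a carboxylic acid or a longer chain at this carbon would read, and the true size of the step remains unknown.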